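Moving the methoxy group from compound 2 to compound 4

The compounds below may be only part of what the source reports. "The series", "measured", "known", "first", "only" and "open" are said of these compounds alone.

Results in a functional assay on A549 cells (Homo sapiens) for antiproliferative activity, read by MTT assay, with a stated time of 72 h (on this read-out lower numbers stand for stronger inhibition and higher numbers for weaker inhibition), follow
- compound 1 `CC/C=C/C(=O)Nc1cccc(Oc2nc(Nc3cccc(OC)c3)nc3c2CSCC3)c1` gives 17200 nM
- compound 2 `CCC/C=C/C(=O)Nc1cccc(Oc2nc(Nc3cccc(OC)c3)nc3c2CSCC3)c1` gives 11800 nM
- compound 3 `C=C(F)C(=O)Nc1cccc(Oc2nc(Nc3cccc(OC)c3)nc3c2CSCC3)c1` gives 29600 nM

Compound 2 cannot be separated from compound 1 on these numbers (a 1.5-fold lower number from compound 1 to compound 2 (0.16 log units; within the scatter)). It does stand apart from compound 3 (a 2.5-fold higher number from compound 2 to compound 3 (0.40 log units; beyond the scatter)), on the side of stronger inhibition. The third comparison (a 1.7-fold higher number from compound 1 to compound 3 (0.24 log units; within the scatter)) stays within the usual spread of repeat measurements.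

The next compound is compound 4 `CCC/C=C/C(=O)Nc1cccc(Oc2nc(Nc3ccc(OC)cc3)nc3c2CSCC3)c1`, which differs from compound 2 in one place (4-methoxyphenyl in place of 3-methoxyphenyl on a nitrogen on an aromatic ring). The two have the same atoms, joined differently: 4-methoxyphenyl stands in place of 3-methoxyphenyl on a nitrogen on an aromatic ring.

Among the compounds with values here, none of the measured steps touches this group. All three alter the group on the carbonyl side and keep the 3-methoxyphenyl unchanged, so they bear on the question only indirectly. They show that the numbers in this small set have moved modestly at most, and they give no direction for the new change. No step beyond the scatter is therefore expected, though the range is kept wide because no direct comparison exists. The expected step is a 1.0-fold higher number from compound 2 to compound 4 (0.01 log units; within the scatter), with neither direction favoured. In this assay, compound 4 is estimated at 12000 nM, with an expected range of 5000 nM to 28000 nM.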

Compound 4, half-maximal inhibitory concentration: 11900 nM
The estimate for compound 4 lay 1.0-fold (0.00 log units) above the measured number; measured number inside the range.
By their numbers in this assay, from the lowest: compounds 2, 4, 1 and 3 (each within the scatter of the next, the first and the last beyond it).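

In this assay, within the data shown here, the first comparison to touch the group on the nitrogen is a 1.0-fold higher number from compound 2 to compound 4 (0.00 log units; within the scatter), so the 3-methoxyphenyl and 4-methoxyphenyl isomers cannot be told apart on this read-out. Compounds 1, 2 and 3 differ only on the carbonyl side and all carry 3-methoxyphenyl, so they could say nothing about where the methoxy group sits on this ring; this pair shows that, with pent-1-en-1-yl on the carbonyl carbon, the two placements give no readable difference. No evidence is available that bears on why the two isomers read alike.

From the compounds shown here alone, it remains open whether the two placements would also read alike with but-1-en-1-yl or 1-fluoroethenyl on the carbonyl carbon, as in compound 1 and compound 3. Nor do these compounds show whether the methoxy group matters at all, since a plain phenyl, a 4-chlorophenyl or a phenyl bearing a carboxylic acid or an amine on the same nitrogen could read differently from compound 2 and compound 4.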